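Swapping a Furan for an Indole on a Shared Core

The compounds below may be only part of what the source reports. "The series", "measured", "known", "first", "only" and "open" are said of these compounds alone.

Cell toxicity is worth checking early, since a compound is useful only at doses that cells can tolerate. In a toxicity assay on MT4 cells (Homo sapiens) for cytotoxicity, read by MTT assay, with a stated time of 5 days (a lower number here means that less compound is tolerated, a higher number that more compound is tolerated), compound 1 (`Cc1cnc(Nc2ccc(C#N)cc2)nc1Nc1c(F)cc(-c2cc(F)nc(F)c2)cc1F`) gives 103000 nM. Compound 2 (`Cc1cc(-c2ccco2)cc(C)c1Nc1ccnc(Nc2ccc(C#N)cc2)n1`) gives 1700 nM, the lower of the two numbers, and the gap between them lies beyond the usual scatter.

Compound 3 (`Cc1cc(-c2cccc3cc[nH]c23)cc(C)c1Nc1ccnc(Nc2ccc(C#N)cc2)n1`) keeps the rest of compound 2 but carries 1H-indol-7-yl in place of furan-2-yl on an aromatic carbon. That carbon belongs to a six-membered aromatic ring of carbon only, meta to two methyl groups.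

For the measured compounds named here, no pair of measured compounds differs in one place only, so the data give no direct guide to this swap. The only hint is weak: compound 2, at 1700 nM, is the low point so far, and compound 1 shows that much higher numbers occur in this assay. A moderate upward step, only just beyond the scatter, is therefore expected, and the estimated step is a 2.9-fold higher number from compound 2 to compound 3 (0.47 log units; beyond the scatter). For compound 3 the expected value is 5000 nM, with an estimated range of 1500 nM to 30000 nM.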

Compound 3, half-maximal cytotoxic concentration: 1000 nM
Compound 3: middle estimate off by 5.0-fold (0.70 log units), on the high side; the measured number lies below the stated range.
By their numbers in this assay, from the lowest: compounds 3 and 2 (each within the scatter of the next); then compound 1.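

Putting 1H-indol-7-yl in place of furan-2-yl gives a 1.7-fold lower number from compound 2 to compound 3 (0.23 log units; within the scatter) in this assay, so this single change does not separate the two compounds. For the compounds shown here, this is the first direct reading at this aromatic carbon: a six-membered aromatic ring of carbon only is added to the five-membered ring, and a hydrogen-bond acceptor gives way to a hydrogen-bond donor, yet the two numbers stay within the usual scatter of each other. No separate measurement shown here accounts for this result.

From the compounds shown here alone, whether an amine, a carboxylic acid or a longer chain on this same carbon would also stay within the scatter of compound 2 remains open, since furan-2-yl and 1H-indol-7-yl are both aromatic rings and the step between them says nothing about groups of other kinds. Compound 2 and compound 3 differ from compound 1 in more than one place, so the value of compound 1 at 103000 nM cannot be tied to any single change, and what sets that number apart remains unresolved.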